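The source may hold more compounds than are shown below. What is called first, only, known or untested is meant among the compounds shown, and "the series" means these compounds.

Measured in a functional assay on MCF7 cells (Homo sapiens) for cytotoxicity, read by MTT assay, with a stated time of 72 h, tested at 100 uM; a higher number here means more inhibition of growth at the concentration tested, a lower number less inhibition of growth:
- compound 1 `N/C(=N\NC(=S)N1CCOCC1)c1ccccn1`: 81.6%
- compound 2 `N/C(=N\NC(=S)N1CCCC1)c1ccc(F)cn1`: 73%
- compound 3 `N/C(=N\NC(=S)N1CCSCC1)c1ccc(F)cn1`: 65.7%

Compound 3 stands lowest of the three numbers, within the scatter of compound 2 and beyond it against compound 1. Compound 4 `N/C(=N\NC(=S)N1CCOCC1)c1ccc(F)cn1` is the next member; the change is morpholin-4-yl in place of thiomorpholin-4-yl on a thiocarbonyl carbon. For the measured compounds named here, no measured step swaps these two six-membered rings directly. Going by the values given here, the one step at the same place, a number 7.3 percentage points lower from compound 2 to compound 3 (within the scatter), was within the scatter, and compound 1, which carries the morpholin-4-yl on a different core, reads higher than compound 3. For compound 4 the expected step is therefore a number 6.3 percentage points higher from compound 3 to compound 4 (within the scatter), a modest rise. Compound 4 is estimated at 72%, range 60% to 84%.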

Compound 4, percent growth inhibition at one concentration: 61.5%
Beside the measured number, compound 4's estimate is 10.5 percentage points above it; low and high end bracket the measured number.
By their numbers in this assay, from the lowest: compounds 4, 3, 2 and 1 (each within the scatter of the next, the first and the last beyond it).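

In this assay, the direct swap of the two six-membered rings (a number 4.2 percentage points lower from compound 3 to compound 4 (within the scatter)) does not separate morpholin-4-yl from thiomorpholin-4-yl on the thiocarbonyl carbon. For the compounds shown here, at the same place, morpholin-4-yl in place of pyrrolidin-1-yl (a number 11.5 percentage points lower from compound 2 to compound 4 (beyond the scatter)) is the first step there to pass the scatter. Fluoro in place of hydrogen on an aromatic carbon (a number 20.1 percentage points lower from compound 1 to compound 4 (beyond the scatter)) also passes it, the first reading of that change in the series.

No evidence on the cause of either larger step is at hand. Going by these compounds, how piperidin-1-yl or an open-chain dimethylamino group on the thiocarbonyl carbon, or chloro in place of fluoro, reads remains open.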